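The source may hold more compounds than are shown below. What is called first, only, known or untested is meant among the compounds shown, and "the series" means these compounds.

Measured compounds:
compound 1 `Cc1ccc(-n2cc(Cn3nc(N)c4c(C(F)(F)F)cc(-c5ccccc5)nc43)nn2)cc1` — 98.6 ug/mL
compound 2 `Nc1nn(Cc2cn(-c3ccc(O)c([N+](=O)[O-])c3)nn2)c2nc(-c3ccccc3)cc(C(F)(F)F)c12` — 36.3 ug/mL

In a functional assay on THP-1 cells (Homo sapiens) for cytotoxicity, read by MTT assay, with a stated time of 24 h (a lower number here means a stronger inhibitor, a higher number a weaker inhibitor), compound 1 stands at the highest of the two numbers; compound 2 sits a 2.7-fold lower number from compound 1 to compound 2 (0.43 log units; beyond the scatter) from it. Compound 3 `Nc1nn(Cc2cn(CC(=O)Nc3cccc(Cl)c3)nn2)c2nc(-c3ccccc3)cc(C(F)(F)F)c12` is yet to be measured; it differs from compound 1 by ((3-chlorophenyl)carbamoyl)methyl in place of 4-methylphenyl on an aromatic nitrogen. For the measured compounds named here, the one measured step that bears on this position, a 2.7-fold lower number from compound 1 to compound 2 (0.43 log units; beyond the scatter), was modest, and the entering group here is of a different kind, so only a small lowering or none beyond the scatter is expected. Compound 3 is estimated at 55 ug/mL (range 20 ug/mL to 130 ug/mL), an expected step of a 1.8-fold lower number from compound 1 to compound 3 (0.25 log units; within the scatter).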

Compound 3, half-maximal inhibitory concentration: 37 ug/mL
The estimate for compound 3 lay 1.5-fold (0.17 log units) above the measured number; the measured number falls inside the stated range.
By their numbers in this assay, from the lowest: compounds 2 and 3 (each within the scatter of the next); then compound 1.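

In this assay, ((3-chlorophenyl)carbamoyl)methyl on the aromatic nitrogen also moves the number away from the 4-methylphenyl compound (a 2.7-fold lower number from compound 1 to compound 3 (0.43 log units; beyond the scatter)), so compound 2 is no longer the only replacement to do so. The two replacements are not separated (a 1.0-fold higher number from compound 2 to compound 3 (0.01 log units; within the scatter)), although they share only a six-membered aromatic ring of carbon. No measurement bears on why these two different groups land level.

The chlorine and the amide are not varied apart, so neither can be credited with the step. Going by these compounds, whether an unsubstituted phenyl, a carboxylic acid or an amine on this nitrogen would fall level with compound 2 and compound 3 remains open.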